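Taking One Methyl Off a Weakly Cytotoxic Compound

The source may report more compounds than this note shows. Statements on the series, on what has been measured and on what is new or still open speak of the compounds shown alone.

In a functional assay on B16 cells (Mus musculus) for cytotoxicity, read by MTT assay, with a stated time of 48 h (a lower number here means a stronger inhibitor, a higher number a weaker inhibitor), compound 1 `CC1(C)CCCC2=CC=C(C=O)CC[C@]21C` gives 145000 nM and compound 2 `C=C1CCC[C@]2(C)CCC(c3cn(CC(=O)Nc4ccc(C)cc4)nn3)=CC[C@@]12C` gives 210000 nM as its result. These two numbers lie within the usual scatter of each other, so compound 2 stands level with compound 1, and no order can be read between them.

Compound 3 `C=C1CCC[C@]2(C)CCC(c3cn(CC(=O)Nc4ccccc4)nn3)=CC[C@@]12C` departs from compound 2 at one spot: hydrogen in place of methyl on an aromatic carbon in all. This is hydrogen in place of methyl on an aromatic carbon, so 4-methylphenyl becomes phenyl. Among the compounds with values here, no measured pair of compounds shows a change of this kind. For this assay I therefore expect no step beyond the scatter, and I name no direction. The estimated step of a 1.1-fold lower number from compound 2 to compound 3 (0.02 log units; within the scatter) is small. The expected value for compound 3 is 200000 nM with an estimated range of 100000 nM to 400000 nM around it.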

Compound 3, half-maximal inhibitory concentration: 149000 nM
For compound 3 the middle estimate is 1.3-fold (0.13 log units) above the measured one; the measured number falls inside the stated range.
By their numbers in this assay, from the lowest: compounds 1, 3 and 2 (each within the scatter of the next).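

In this assay, going from 4-methylphenyl to phenyl gives a 1.4-fold lower number from compound 2 to compound 3 (0.15 log units; within the scatter), so this pair reveals no effect of the methyl on this aromatic carbon, para to a large group. For this one change, then, the methyl can be exchanged for hydrogen without the result moving beyond the usual scatter of the assay. No measurement at hand offers a reason for this result.

The compounds shown leave open whether a different group on this carbon, such as a chlorine atom, a methoxy group or a carboxylic acid, would shift the number beyond the scatter. They also leave open whether replacing the whole phenyl with a longer carbon chain or an amine-bearing group would change the result.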